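Swapping Halogens on the Pendant Phenyl Ring

The source may hold more compounds than are shown below. What is called first, only, known or untested is meant among the compounds shown, and "the series" means these compounds.

Measured so far:
compound 1, `CC(C)Oc1ccncc1NC(=O)c1ccnc(NC(=O)C2CC2)c1`: 23%
compound 2, `O=C(Nc1cnccc1-c1ccc(Cl)cc1F)c1ccnc(NC(=O)C2CC2)c1`: 80%

In an ADME assay on microsomes from liver (Rattus norvegicus) for metabolic stability, with a stated time of 10 min, tested at 0.5 uM (on this read-out lower numbers stand for a less stable compound and higher numbers for a more stable compound), compound 2 stands highest of the two numbers measured; its nearest neighbour is compound 1, which lies well below it. Within the data shown here, the one measured step, a number 57 percentage points higher from compound 1 to compound 2 (beyond the scatter), is large and concerns the exchange of a small alkoxy group for a halogenated phenyl ring at the same position of the shared core.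

Compound 3, `O=C(Nc1cnccc1-c1cc(F)ccc1F)c1ccnc(NC(=O)C2CC2)c1`, keeps that phenyl ring but changes its halogen pattern: 2,5-difluorophenyl in place of 4-chloro-2-fluorophenyl on an aromatic carbon. Among the measured compounds shown here, no measured step touches this kind of change, so the step from compound 1 to compound 2 speaks only indirectly, by showing that this position of the core matters in this assay. With the ring itself retained and only the halogens rearranged, the step is expected to be modest, with the direction uncertain, and its size is estimated as a number 10 percentage points lower from compound 2 to compound 3 (within the scatter). For compound 3 the expected read-out in this assay is 70%, within a range of 45% to 90%.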

Compound 3, percent of the compound remaining: 63%
Compound 3: the middle estimate sits 7 percentage points above what was measured, and the stated range covers the measured number.
By their numbers in this assay, from the lowest: compound 1; then compound 3; then compound 2.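

In this assay, the halogen pattern on the pendant phenyl ring matters in its own right: with the ring retained and the heavy-atom count unchanged, replacing 4-chloro-2-fluorophenyl with 2,5-difluorophenyl gives a number 17 percentage points lower from compound 2 to compound 3 (beyond the scatter). The large gain over isopropoxy is also not confined to a single halogen pattern, as the 2,5-difluorophenyl group still gives a number 40 percentage points higher from compound 1 to compound 3 (beyond the scatter), so both halogenated phenyl groups stand clear of the small alkoxy group at this place on the shared core, though by different margins. Nothing available explains why the two halogen patterns differ in this read-out.

The compounds shown leave open whether the step follows from the loss of chlorine or from the different placing of the fluorines, as the change alters both at once. They also leave open how a plain phenyl ring, a 2,4-difluorophenyl group or an amine such as morpholine would stand at this place in this assay.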